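This account rests on a few compounds, and the source may have more. Where it says the series, first, only, none or still open, it means among the compounds named here.

Values in a functional assay, with a stated time of 10 min (on this read-out higher numbers stand for weaker inhibition and lower numbers for stronger inhibition), are as follows:

- compound 1 (`CCCCOc1cc(OC)c(Br)cc1C(C)=O`) gives 56900000 nM
- compound 2 (`CCCCCCOc1cc(OC)c(Br)cc1C(C)=O`) gives 53100000 nM
- compound 3 (`CCCCCCCCOc1cc(OC)c(Br)cc1C(C)=O`) gives 38100000 nM

On these numbers, compound 3 cannot be told apart from the other two compounds. Both a 1.5-fold lower number from compound 1 to compound 3 (0.17 log units; within the scatter) and a 1.4-fold lower number from compound 2 to compound 3 (0.14 log units; within the scatter) lie within the scatter.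

The next compound is compound 4 (`CCCCCCCCCCOc1cc(OC)c(Br)cc1C(C)=O`). The structural change (ethyl in place of hydrogen on a saturated chain carbon, eight bonds along the chain from an oxygen on an aromatic ring) places ethyl in place of hydrogen on a saturated chain carbon, eight bonds along the chain from an oxygen on an aromatic ring. The closest precedents are a 1.1-fold lower number from compound 1 to compound 2 (0.03 log units; within the scatter) and a 1.4-fold lower number from compound 2 to compound 3 (0.14 log units; within the scatter), both ethyl in place of hydrogen on the same chain and both within the scatter. The larger butyl change, the step already cited from compound 1, also stayed within it. In this assay no step beyond the scatter is therefore expected. The expected size is a 1.1-fold lower number from compound 3 to compound 4 (0.02 log units; within the scatter) and no more. For compound 4 the estimated value is 36000000 nM (expected range 16000000 nM to 70000000 nM).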

Compound 4, half-maximal inhibitory concentration: 29700000 nM
The estimate for compound 4 lay 1.2-fold (0.08 log units) above the measured number; low and high end bracket the measured number.
By their numbers in this assay, from the lowest: compounds 4, 3, 2 and 1 (each within the scatter of the next).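

In this assay, ethyl in place of hydrogen on a saturated chain carbon, eight bonds along the chain from an oxygen on an aromatic ring, gives a 1.3-fold lower number from compound 3 to compound 4 (0.11 log units; within the scatter), so the chain extended this far still cannot be told apart from the one before it. The wider spans add that even the larger changes stay within the scatter, with a 1.8-fold lower number from compound 2 to compound 4 (0.25 log units; within the scatter) for butyl and a 1.9-fold lower number from compound 1 to compound 4 (0.28 log units; within the scatter) for hexyl, and the butyl change reads alike on two cores: the same change on two cores in this assay, a 1.5-fold lower number (0.17 log units; within the scatter) from compound 1 to compound 3 and a 1.8-fold lower number (0.25 log units; within the scatter) from compound 2 to compound 4, 1.2-fold (0.08 log units) apart, within the scatter of two such steps The ethyl change likewise reads alike where it is made at two places on the chain: the same change on two cores in this assay, a 1.1-fold lower number (0.03 log units; within the scatter) from compound 1 to compound 2 and a 1.3-fold lower number (0.11 log units; within the scatter) from compound 3 to compound 4, 1.2-fold (0.08 log units) apart, within the scatter of two such steps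

The compounds shown leave open whether a longer chain, or a chain ending in an amine or a carboxylic acid, would give a step beyond the scatter. With every step here inside it, no chain among them stands apart from the others.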